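A Bromo Substituent Added to the Anilide of Compound 3

This account rests on a few compounds, and the source may have more. Where it says the series, first, only, none or still open, it means among the compounds named here.

Compound 1 `O=C(Nc1ccccc1O)c1c(NO)cc(-c2ccccc2)oc1=O` gives 14000 nM in an ADME assay on Huh-7 cells (Homo sapiens) for cytotoxicity, with a stated time of 3 days; a lower number here means that less compound is tolerated, a higher number that more compound is tolerated.
Compound 2 `COc1ccc(-c2cc(NO)c(C(=O)NC3CCCCC3)c(=O)o2)cc1` gives 13900 nM in this assay.
Compound 3 `O=C(Nc1ccccc1)c1c(NO)cc(-c2cccs2)oc1=O` gives > 20000 nM in this assay, which is a limit of the assay and not a number.

Compound 3 thus stands at the limit of > 20000 nM in this assay, at which 1 of the 3 values shown sits; how it compares with compound 1 and compound 2 cannot be read from these values. Compound 4 `O=C(Nc1ccc(Br)cc1)c1c(NO)cc(-c2cccs2)oc1=O` differs from compound 3 by a single change, (bromo in place of hydrogen on an aromatic carbon), bromo in place of hydrogen on an aromatic carbon. Among the compounds with values here, no pair of measured compounds shows this change, so its effect in this assay cannot be taken from the data; the expectation is a step no larger than the scatter, in no fixed direction. Compound 4 is therefore expected to give 20000 nM (range 9000 nM to 45000 nM), an estimated step of a number no higher from compound 3 to compound 4 (the limit leaves the size open), most likely reported again as a limit rather than a number.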

Compound 4, half-maximal cytotoxic concentration: > 20000 nM
Compound 4 gave a limit, no number; the forecaster's own chance of this, stated with the estimate: 60%; the middle value sits exactly at the limit.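

In this assay, within the data shown here, compound 3 and compound 4 both give only a limit, and no step between them can be read. The compounds shown leave open what bromo in place of hydrogen does here.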